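A Furan Swap on a Weak Phosphodiesterase Inhibitor Series

The compounds below may be only part of what the source reports. "The series", "measured", "known", "first", "only" and "open" are said of these compounds alone.

Four compounds share one fused bicyclic core, and three of them have been tested in an assay on isolated protein for inhibition of high affinity 3',5'-cyclic-AMP phosphodiesterase 7A (Homo sapiens), read by cAMP accumulation, with a stated time of 20 min; a lower number here means a stronger inhibitor, a higher number a weaker inhibitor. Compound 1 `CCCCCn1c(-c2ccccc2)nc2c(NCCCO)ccnc21` and compound 2 `OCCCNc1ccnc2c1nc(-c1ccco1)n2C1CCCC1` carry the same hydroxypropylamino group, while compound 3 `CCCCCn1c(-c2ccccc2)nc2c(NCc3ccccc3)nccc21` carries a benzylamino group instead.

For compound 1 this assay reports only a limit, > 200000 nM. Compound 2 gives a measured number, 88000 nM. For compound 3 this assay again reports only a limit, > 200000 nM. Within the data shown here, compound 3 thus sits where compound 1 also sits, at the limit of > 200000 nM in this assay, at which 2 of the 3 values shown sit, and nothing measured so far places it more exactly.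

Compound 4 `CCCCCn1c(-c2ccco2)nc2c(NCc3ccccc3)nccc21` differs from compound 3 in one place: furan-2-yl in place of phenyl on an aromatic carbon. Among the measured compounds shown here, no pair of measured compounds differs in exactly this way. For the measured compounds named here, compound 2 is the only measured compound with a furan-2-yl group, and it gives a number where the two phenyl compounds give a limit, but compound 2 also differs from compound 1 in another place, so the two values show no isolated step for the furan alone.

The step of an at least 1.5-fold lower number from compound 3 to compound 4 (0.18 log units; that floor lies within the scatter) is expected to run toward somewhat stronger inhibition, though not clearly beyond the scatter. Compound 4 is estimated at 130000 nM, with a range from 40000 nM to 300000 nM.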

Compound 4, half-maximal inhibitory concentration: > 200000 nM
Compound 4: only a limit was reported (the forecaster's own chance of this, stated with the estimate: 50%); middle value at least 1.5-fold (0.18 log units) away from the limit.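

In this assay compound 4 gives > 200000 nM as its result, which is only a limit. Compound 3 also gives only a limit, so no step can be read between compound 3 and compound 4. The compounds shown leave open whether furan-2-yl in place of phenyl alters inhibition on this core, with most results resting at one limit: the limit of > 200000 nM in this assay, at which 3 of the 4 values shown sit.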